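Swapping the aryl on the carbonyl: from dimethoxy to difluoro

The source may hold more compounds than are shown below. What is called first, only, known or untested is meant among the compounds shown, and "the series" means these compounds.

Measured compounds:
- compound 1, `COc1cc(-c2cc(/C=C/C(=O)c3ccc(N)cc3)[nH]n2)cc(OC)c1OC`, 90%
- compound 2, `COc1ccc(C(=O)/C=C/c2cc(-c3cc(OC)c(OC)c(OC)c3)n[nH]2)cc1OC`, 96%

Both compounds were tested in a functional assay on SK-MEL-28 cells (Homo sapiens) for cytotoxicity, read by sulforhodamine B assay, with a stated time of 48 h, tested at 1 uM; on this read-out lower numbers stand for a stronger effect and higher numbers for a weaker effect at the one concentration tested. Compound 1 gives 90% and compound 2 gives 96%, so at this concentration neither reduces cell growth by much. On the numbers shown, compound 2 has the highest of the two values, but the only step to it, a number 6 percentage points higher from compound 1 to compound 2 (within the scatter), lies within the scatter, so the two compounds cannot be told apart.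

Compound 3, `COc1cc(-c2cc(/C=C/C(=O)c3ccc(F)c(F)c3)[nH]n2)cc(OC)c1OC`, has not yet been measured. It differs from compound 2 in one place: 3,4-difluorophenyl in place of 3,4-dimethoxyphenyl on a carbonyl carbon. For the measured compounds named here, the one measured step bears directly on this change, since it also swapped the aryl group sitting on the carbonyl carbon: the step of a number 6 percentage points higher from compound 1 to compound 2 (within the scatter) was within the scatter. A second swap of the same kind is therefore expected to give no step beyond the scatter in this assay, in either direction.

The estimate for compound 3 in this assay is 92%, within 78% to 100%. This means an expected step of a number 4 percentage points lower from compound 2 to compound 3 (within the scatter), which is within the scatter.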

Compound 3, a percentage reported as activity, at one concentration (the size of the read-out at that concentration, not a potency): 98%
Estimate against measurement, compound 3: 6 percentage points below, within the range that was stated.
By their numbers in this assay, from the lowest: compounds 1, 2 and 3 (each within the scatter of the next).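

In this assay the swap of 3,4-dimethoxyphenyl for 3,4-difluorophenyl on the carbonyl carbon gives a number 2 percentage points higher from compound 2 to compound 3 (within the scatter) and the swap of 4-aminophenyl for the same group gives a number 8 percentage points higher from compound 1 to compound 3 (within the scatter) so all three aryl groups tried at this position cannot be told apart. The new compound adds a further kind of change: 3,4-difluorophenyl has no hydrogen-bond acceptors and carries fluorine where 3,4-dimethoxyphenyl carries oxygen, yet this difference leaves no step beyond the scatter at the one concentration tested. Nothing at hand explains why these three numbers sit so close together.

The compounds shown leave open whether any group on this carbonyl carbon can shift the read-out, as all three values lie close together and come from a single concentration. Going by these compounds, a phenyl ring bearing a carboxylic acid, or a longer chain in place of the aryl group, would probe this position further, and what a change to the shared core would do also remains open.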